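Cyclohexyl in place of cyclopropyl: an expected clearance step

The source may report more compounds than this note shows. Statements on the series, on what has been measured and on what is new or still open speak of the compounds shown alone.

Compound 1 `CNc1nc(S(=O)(=O)c2ccc(N)nc2)ccc1-c1ccc(C(C)(O)C(F)(F)F)cn1` gives 21 mL.min-1.g-1 in an ADME assay (liver) for metabolic stability, with Liver microsome (Rattus norvegicus) as the target, using microsomes and NADPH, with a stated time of 30 min, at 37 degrees C, tested at 1 uM (a higher number here means faster removal of the compound, a lower number slower removal), here
Compound 2 `CC(O)(c1ccc(-c2ccc(S(=O)(=O)c3ccc(N)nc3)nc2NC2CC2)nc1)C(F)(F)F` gives 43 mL.min-1.g-1 in this assay here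

Of the two measured compounds, compound 2 holds the higher number. Compound 3 `CC(O)(c1ccc(-c2ccc(S(=O)(=O)c3ccc(N)nc3)nc2NC2CCCCC2)nc1)C(F)(F)F` differs from it by cyclohexyl in place of cyclopropyl on a nitrogen on an aromatic ring as cyclohexyl in place of cyclopropyl on a nitrogen on an aromatic ring. Within the data shown here, one measured step bears on this change, at that same place: a 2.0-fold higher number from compound 1 to compound 2 (0.31 log units; beyond the scatter) on going from methyl to cyclopropyl, a modest rise. No cyclohexyl has been measured, so a further rise of similar size is expected, namely a 1.9-fold higher number from compound 2 to compound 3 (0.27 log units; within the scatter) as the estimate. Compound 3 is expected at 80 mL.min-1.g-1 with an estimated range of 45 mL.min-1.g-1 to 140 mL.min-1.g-1 in all.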

Compound 3, intrinsic clearance in microsomes: 280 mL.min-1.g-1
Compound 3: middle estimate off by 3.5-fold (0.54 log units), on the low side, outside the stated range (above it).
By their numbers in this assay, from the lowest: compound 1; then compound 2; then compound 3.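

In this assay, the number rises with each of the three groups on this nitrogen on an aromatic ring, and the rise is not even: cyclohexyl in place of cyclopropyl brings a 6.5-fold higher number from compound 2 to compound 3 (0.81 log units; beyond the scatter), and the whole span from methyl brings a 13-fold higher number from compound 1 to compound 3 (1.12 log units; beyond the scatter). This one change at this position thus moves the number far more than the methyl to cyclopropyl change did. Nothing at hand explains the size of this jump. Still open, going by these compounds, is where an isopropyl group or a tetrahydropyranyl ring on this nitrogen would fall.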